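Anilide variation in a dopamine D(4) agonist series

The source may report more compounds than this note shows. Statements on the series, on what has been measured and on what is new or still open speak of the compounds shown alone.

Compound 1 `O=C(NCN1CCC(c2cccc[n+]2[O-])CC1)c1ccccc1`: 532 nM in a functional assay on HEK293 cells for agonist activity at D(4) dopamine receptor (Homo sapiens), read by FLIPR; on this read-out lower numbers stand for an effect already at smaller amounts and higher numbers for an effect only at larger amounts of compound
Compound 2 `Cc1cc(C)cc(NC(=O)CN2CCC(c3cccc[n+]3[O-])CC2)c1`: 52 nM in this assay

Of the two measured numbers in this assay, compound 2 has the lower one, and the value of compound 1 lies above it by a gap beyond the usual scatter. Compound 3 `Cc1cc(Br)ccc1NC(=O)CN1CCC(c2cccc[n+]2[O-])CC1` differs from compound 2 by 4-bromo-2-methylphenyl in place of 3,5-dimethylphenyl on an amide-type nitrogen. For the measured compounds named here, no measured pair isolates a change of this kind, so the direction rests on the structural change alone. The expected step is a 1.9-fold higher number from compound 2 to compound 3 (0.28 log units; within the scatter), small and toward higher numbers, close to the scatter. Compound 3 is therefore estimated at 100 nM, with a range from 30 nM to 350 nM.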

Compound 3, half-maximal effective concentration: 66 nM
The estimate for compound 3 lay 1.5-fold (0.18 log units) above the measured number; low and high end bracket the measured number.
By their numbers in this assay, from the lowest: compounds 2 and 3 (each within the scatter of the next); then compound 1.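

On an amide-type nitrogen, 4-bromo-2-methylphenyl in place of 3,5-dimethylphenyl gives a 1.3-fold higher number from compound 2 to compound 3 (0.10 log units; within the scatter) in this assay. This first matched pair shows that this position tolerates a change in the pattern of ring substituents, including a bromine atom, with no shift beyond the scatter. Nothing measured accounts for this result.

This single pair cannot separate the contribution of the bromine from that of the altered methyl substitution. Going by these compounds, whether an amine or a carboxylic acid on this phenyl ring would be tolerated as well remains open.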